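The compounds below may be only part of what the source reports. "The series", "measured", "known", "first", "only" and "open" are said of these compounds alone.

Series notes. In an assay on HEK293 cells for agonist activity at transient receptor potential cation channel subfamily M member 8 (Homo sapiens), read by fluorescence and calcium flux, with a stated time of 15 min (a lower number here means that less compound is needed, a higher number that more compound is needed for the effect), compound 1 `Cc1ccc(OCC(=O)N(Cc2cccs2)c2ncccn2)cc1` gives 3700 nM, compound 2 `Cc1ccc(OCC(=O)N(CCO)Cc2cccs2)cc1` gives 900 nM and compound 3 `Cc1ccc(OCC(=O)N(Cc2cccs2)c2ccon2)cc1` gives 2 nM. Compound 3 stands lowest of the three, with both steps to it beyond the scatter: a 1900-fold lower number from compound 1 to compound 3 (3.27 log units; beyond the scatter) and a 450-fold lower number from compound 2 to compound 3 (2.65 log units; beyond the scatter). The remaining pair gave a 4.1-fold lower number from compound 1 to compound 2 (0.61 log units; beyond the scatter). Next is compound 4 `CCC(C)N(Cc1cccs1)C(=O)COc1ccc(C)cc1`, which changes the same position: sec-butyl in place of 1,2-oxazol-3-yl on an amide-type nitrogen. Both large steps bear on this change: every other group so far placed on this amide-type nitrogen gave a far higher number than the 1,2-oxazol-3-yl of compound 3, and the closer comparison is compound 2, whose 2-hydroxyethyl, like sec-butyl, carries no ring. A large upward step in this assay is therefore expected, of a size comparable to the reverse of those two steps, landing in the region of compound 2 or higher. Compound 4 is expected near 1500 nM, within a range of 300 nM to 8000 nM. The expected step is a 750-fold higher number from compound 3 to compound 4 (2.88 log units; beyond the scatter).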

Compound 4, half-maximal effective concentration: 2000 nM
Compound 4: the middle estimate sits 1.3-fold (0.12 log units) below what was measured, within the range that was stated.
By their numbers in this assay, from the lowest: compound 3; then compound 2; then compounds 4 and 1 (each within the scatter of the next).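

With sec-butyl on this amide-type nitrogen, this assay shows a 1000-fold higher number from compound 3 to compound 4 (3.00 log units; beyond the scatter) and so gives no sign that an all-carbon group without a ring can stand in for 1,2-oxazol-3-yl. Against the other ringless group, sec-butyl shows a 2.2-fold higher number from compound 2 to compound 4 (0.35 log units; beyond the scatter), a modest step set against the large one. Against pyrimidin-2-yl it shows a 1.9-fold lower number from compound 1 to compound 4 (0.27 log units; within the scatter), so among the four compounds a ring alone does not bring the number down, and the low value remains with 1,2-oxazol-3-yl only. Nothing shown on these compounds accounts for the difference among these groups.

Open, from the compounds shown here alone, is whether a close relative such as 1,2-oxazol-5-yl, thiazol-2-yl or 5-methyl-1,2-oxazol-3-yl keeps the low number. Also open, going by these compounds, is whether a phenyl or a longer alkyl chain on this nitrogen falls nearer compound 3 or compound 4.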